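A few compounds are considered here, and "the series" means these few. Any claim that something is new, unique, unknown or untested is made for them only; others in the source may bear on it.

Compound 2 `Cn1cncc1C(OCc1ccc(C#N)cc1C#CCCCCO)c1ccc(C#N)cc1` holds the only number shown in a functional assay on NIH3T3 cells (Mus musculus) (a lower number here means that less compound is needed, a higher number that more compound is needed for the effect), where compound 2 gives 20.9 nM. Compound 1 `Cn1cncc1C(OCc1ccc(C#N)cc1C#Cc1ccc(-c2ccccc2)cc1)c1ccc(C#N)cc1` stands only at a limit of the assay in this assay, > 0.1 nM. The step that the limit leaves unreadable from compound 1 to compound 2 therefore cannot be read, which the limit of > 0.1 nM in this assay, at which 1 of the 2 values shown sits, records. Compound 3 `Cn1cncc1C(OCc1ccc(C#N)cc1CCC(C)(C)C)c1ccc(C#N)cc1` differs from compound 2 by 3,3-dimethylbutyl in place of 6-hydroxyhex-1-yn-1-yl on an aromatic carbon. For the measured compounds named here, no measured step bears readably on this change, so the data give no direction for it. Compound 3 is estimated at 25 nM, in a range from 5 nM to 120 nM. The step of a 1.2-fold higher number from compound 2 to compound 3 (0.08 log units; within the scatter) is expected to stay within the usual scatter.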

Compound 3, half-maximal effective concentration: 0.54 nM
Estimate against measurement, compound 3: 46-fold (1.67 log units) above, and the stated range ends above it.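

For the compounds shown here, the change gives a 39-fold lower number from compound 2 to compound 3 (1.59 log units; beyond the scatter) in this assay, the first readable step at this aromatic carbon, since the earlier step cannot be read. Less compound is needed with 3,3-dimethylbutyl, which has no triple bond and no hydrogen-bond donor or acceptor, so this position responds strongly to the group it carries. Nothing measured here explains the size of this step.

Going by these compounds, because the hydroxyl and the triple bond leave together, their separate shares stay open. A saturated six-carbon chain ending in hydroxyl, or a chain ending in an amine, would bear on that question.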